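The compounds below may be only part of what the source reports. "The series", "measured", "known", "first", "only" and "open" are said of these compounds alone.

Compound 1 `COc1cc(-c2nn(-c3cccc(NC(=O)Nc4ccc(Cl)c(Cl)c4)c3)cc2-c2ccncc2)ccc1Cl` carries a diaryl urea on the shared core with a methoxy group on the chloro-substituted ring. For the measured compounds named here, in a functional assay on HCC 2998 cells (Homo sapiens) for inhibition, read by sulforhodamine B assay, with a stated time of 48 h (a higher number here means a weaker inhibitor of growth, a lower number a stronger inhibitor of growth), compound 1 gives 6200 nM, the lowest of the two numbers so far. Going by the values given here, the only neighbour measured is compound 2 `O=C(Nc1cccc(-n2cc(-c3ccncc3)c(-c3ccc(Cl)c(O)c3)n2)c1)Nc1ccc(Cl)c(Cl)c1`, which in this assay gives 13900 nM; this is a 2.2-fold higher number from compound 1 to compound 2 (0.35 log units; beyond the scatter), hydrogen in place of methyl on an oxygen on an aromatic ring.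

Compound 3 `COc1cc(-c2nn(-c3cccc(NC(=O)c4ccccc4)c3)cc2-c2ccncc2)ccc1Cl` keeps the methoxy group of compound 1 and changes the urea end instead: phenyl in place of (3,4-dichlorophenyl)amino on a carbonyl carbon. Among the compounds with values here, the urea becomes a benzamide, the (3,4-dichlorophenyl)carbamoyl)amino end becomes benzamido. No measured step touches this position; the step from compound 1 to compound 2 sits on the other side of the molecule and gives no guide to the size or direction here. The only thing the data show is that both measured compounds, with the urea intact, sit in the micromolar range of this assay. Without a measured comparison the estimate must be loose, and a step in the weaker direction is expected, a 2.4-fold higher number from compound 1 to compound 3 (0.38 log units; beyond the scatter). Compound 3 is therefore expected at about 15000 nM in this assay, within 4000 nM to 60000 nM.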

Compound 3, concentration for total growth inhibition: 22400 nM
Compound 3: the middle estimate sits 1.5-fold (0.17 log units) below what was measured, and the stated range covers the measured number.
By their numbers in this assay, from the lowest: compound 1; then compounds 2 and 3 (each within the scatter of the next).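

For the compounds shown here, the urea end of the molecule responds to change: in this assay, the step to the benzamide is a 3.6-fold higher number from compound 1 to compound 3 (0.56 log units; beyond the scatter), the first measured change at this position and one towards weaker growth inhibition. The change does not abolish the read-out, since compound 3 still gives a number in the same assay, so the (3,4-dichlorophenyl)amino group is not required for a measurable value on the shared core. Going by these compounds alone, the single step nevertheless replaces the amino link, with its hydrogen-bond donor, and removes the chlorine atoms together, so it cannot assign the loss to either part, and no available evidence bears on the cause of the shift.

Still open, from the compounds shown here alone, is which part of the (3,4-dichlorophenyl)amino group carries the difference: a 3,4-dichlorophenyl group placed directly on the carbonyl carbon, or an unsubstituted phenylamino group in the same place, would separate the amino link from the chlorine atoms. Also open, going by these compounds, is whether the benzamide end and the hydroxy group of compound 2 act independently, and how a saturated ring such as cyclohexyl or a short alkyl chain on the carbonyl carbon would read.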